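The compounds below may be only part of what the source reports. "The series", "measured", "known", "first", "only" and "open" are said of these compounds alone.

Working notes on the series.

The set rests on a shared core carrying a basic side chain. Compound 1 `COc1ccc(-c2cc(=O)c3c(O)cc(OCCCCN4CCN(C)CC4)c(OC)c3o2)cc1` gives 2320 nM in a functional assay on A549 cells (Homo sapiens) for cytotoxicity, read by MTT assay, with a stated time of 72 h; on this read-out lower numbers stand for stronger inhibition and higher numbers for weaker inhibition. Among the compounds with values here, compound 2 `COc1c(OCCCCN2CCN(C)CC2)cc(O)c2c(=O)cc(-c3ccc(F)cc3)oc12` gives 2220 nM in this assay, and the change between them, a 1.0-fold lower number from compound 1 to compound 2 (0.02 log units; within the scatter), is the only single-point step measured so far. Compound 3 `CCN(CC)CCCOc1c(OCc2ccccc2)cc(O)c2c(=O)cc(-c3ccccc3)oc12` gives 3620 nM in this assay; it carries the highest of the three numbers, yet its gap to compound 1 and its gap to compound 2 both stay within the scatter, so no order can be read among the three.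

Compound 4 `CN(C)CCCCOc1c(OCc2ccccc2)cc(O)c2c(=O)cc(-c3ccccc3)oc12` is not yet measured. It differs from compound 3 by (dimethylamino)methyl in place of diethylamino on a saturated chain carbon, three bonds along the chain from an oxygen on an aromatic ring. Within the data shown here, no measured step touches this part of the molecule: the one step on record, from compound 1 to compound 2, concerns the substituent on the pendant aromatic ring, and compounds 1 and 2 carry a different amine altogether, so they give no single-place comparison for the side-chain amine. With nothing in the data pointing either way, the expectation is a step of a 1.0-fold lower number from compound 3 to compound 4 (0.00 log units; within the scatter), that is none beyond the scatter. Compound 4 is therefore estimated at 3600 nM in this assay, with a range from 1800 nM to 7500 nM.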

Compound 4, half-maximal inhibitory concentration: 1090 nM
For compound 4 the middle estimate is 3.3-fold (0.52 log units) above the measured one; measured number outside the range, below it.
By their numbers in this assay, from the lowest: compound 4; then compounds 2, 1 and 3 (each within the scatter of the next).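

Within the data shown here, the end of the basic side chain is the first place where a single change moves the number beyond the scatter in this assay: replacing 3-(diethylamino)propyl with 4-(dimethylamino)butyl gives a 3.3-fold lower number from compound 3 to compound 4 (0.52 log units; beyond the scatter), a modest step, whereas the only earlier step, on the pendant aromatic ring, gave a 1.0-fold lower number from compound 1 to compound 2 (0.02 log units; within the scatter) and stayed within it. This one change alters the groups on the nitrogen and the length of the chain together, so the pair shows that the combined change matters but cannot assign the step to either part. Nothing at hand bears on why the number falls at this position.

Two side chains would separate these parts: 3-(dimethylamino)propyl would change only the nitrogen groups from compound 3, and 4-(diethylamino)butyl would change only the chain length. Also open, on these data alone, are whether a cyclic amine such as pyrrolidine or morpholine at the chain end keeps the lower number, and whether a chain longer than butyl extends the trend or reverses it.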